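The source may hold more compounds than are shown below. What is called first, only, known or untested is meant among the compounds shown, and "the series" means these compounds.

Measured compounds in a functional assay on the whole organism (strain Swiss albino) for inhibition, with Mus musculus as the target, with stated times of 30 min, 10 min and 20 min; a higher number here means that more compound is needed for the effect, a lower number that less compound is needed:
compound 1 `O=C(CN1CCN(c2cccc(C(F)(F)F)c2)CC1)N(c1ccccc1)c1ccccc1` gives 30 mg/kg
compound 2 `COc1cccc(N2CCN(CC(=O)N(c3ccccc3)c3ccccc3)CC2)c1` gives 15.5 mg/kg

Compound 1 has the highest of the two numbers in this assay; its nearest neighbour is compound 2, and the step of a 1.9-fold lower number from compound 1 to compound 2 (0.29 log units; within the scatter) lies within the scatter, so the two compounds cannot be told apart on these numbers.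

Compound 3 `O=C(CN1CCN(c2ccc(Cl)c(Cl)c2)CC1)N(c1ccccc1)c1ccccc1` has not been measured. It differs from compound 1 in one place: 3,4-dichlorophenyl in place of 3-(trifluoromethyl)phenyl on an amine nitrogen in a ring. Among the measured compounds shown here, no measured step covers this exact exchange. For the measured compounds named here, the only comparison available, the exchange of one substituent on an aromatic carbon from compound 1 to compound 2, gave a step of a 1.9-fold lower number from compound 1 to compound 2 (0.29 log units; within the scatter), within the scatter. A further exchange of the aromatic group on the same amine nitrogen is therefore expected to move the number no farther than the scatter, and no direction is predicted. The estimate for compound 3 in this assay is 25 mg/kg, with a range from 12 mg/kg to 50 mg/kg. This corresponds to an expected step of a 1.2-fold lower number from compound 1 to compound 3 (0.08 log units; within the scatter).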

Compound 3, dose for half-maximal effect: > 20 mg/kg
Compound 3 gave a limit, no number; the forecaster's own chance of this, stated with the estimate: 5%; the middle value does not contradict the limit.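

In this assay compound 3 gives > 20 mg/kg, which is a limit of the assay and not a number. Among the compounds shown here, the only readable step is an at least 1.2-fold higher number from compound 2 to compound 3 (0.11 log units; that floor lies within the scatter), so this change on the amine nitrogen in a ring separates 3,4-dichlorophenyl from 3-methoxyphenyl by no more than the scatter on the present data, while the step from compound 1 to compound 3 cannot be read. Compared with the earlier pair, the series now has a third aromatic group at this position, but its contribution to the reading is only a bound and not a measured position in the order: the limit of > 20 mg/kg in this assay, at which 1 of the 3 values shown sits.

The data leave open where compound 3 actually lies and therefore whether exchanging 3-(trifluoromethyl)phenyl for 3,4-dichlorophenyl moves the number in either direction. They also leave open how the series responds to an unsubstituted phenyl, a nitrile or a carboxylic acid on the aromatic ring, or to a longer chain in place of the one that joins the shared core to the amide carbonyl.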